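Methyl in place of fluoro on compound 1

The source may report more compounds than this note shows. Statements on the series, on what has been measured and on what is new or still open speak of the compounds shown alone.

Of the compounds shown here, three have numbers so far in a functional assay on MCF7 cells (Homo sapiens) for antiproliferative activity, read by MTT assay, with a stated time of 24 h; a higher number here means a weaker inhibitor, a lower number a stronger inhibitor. Compound 1 `O=S(=O)(Nc1ccc2cc[nH]c2c1)c1ccc(F)cc1` gives 30900 nM, compound 2 `N#Cc1ccc(C(=O)Nc2ccc3cc[nH]c3c2)cc1` gives 33600 nM and compound 3 `O=C(Nc1ccc2cc[nH]c2c1)c1ccc(F)cc1` gives 45900 nM. All three values lie within the scatter of one another, so compound 1 stands level with the other two and no order can be read among them.

Compound 4 `Cc1ccc(S(=O)(=O)Nc2ccc3cc[nH]c3c2)cc1` has not yet been measured. Its difference from compound 1 is methyl in place of fluoro on an aromatic carbon, para to a large group.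

Going by the values given here, one measured step bears on this change, and only indirectly. It is a 1.4-fold higher number from compound 2 to compound 3 (0.14 log units; within the scatter), a swap of fluoro for cyano on an aromatic carbon, and it stays within the scatter. Among the compounds with values here, no measured step has methyl entering or leaving, so the data hold no direct precedent. With that single small step as the guide, no change beyond the scatter is expected in this assay. The estimated step is a 1.0-fold higher number from compound 1 to compound 4 (0.02 log units; within the scatter), which is expected to stay within the scatter. Compound 4 is estimated at 32000 nM, with an expected range from 15000 nM to 70000 nM.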

Compound 4, half-maximal inhibitory concentration: 37200 nM
The estimate for compound 4 lay 1.2-fold (0.07 log units) below the measured number; the range from low to high includes it.
By their numbers in this assay, from the lowest: compounds 1, 2, 4 and 3 (each within the scatter of the next).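

Going by these compounds alone, replacing fluoro with methyl on an aromatic carbon, para to a large group, gives in this assay a 1.2-fold higher number from compound 1 to compound 4 (0.08 log units; within the scatter), the first measured step in which methyl takes part. Together with a 1.4-fold higher number from compound 2 to compound 3 (0.14 log units; within the scatter), it shows that three groups on this aromatic ring, namely cyano, fluoro and methyl, have so far produced no step beyond the scatter, and no compound shown goes against this, although the two steps were measured on different linkers. Compound 4 therefore stands level with compounds 1, 2 and 3, and the change gives no handle for separating the series in this assay; no evidence is available on the basis of this result.

From the compounds shown here alone, it remains open whether a larger or charged replacement at this position, such as an amine, a carboxylic acid or a longer chain, would produce a step beyond the scatter. The methyl change also remains to be read on the carbonyl-linked compound 3, which would show whether the same swap stays as small with that linker.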